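From methoxy to methylsulfanyl on the shared core

The source may hold more compounds than are shown below. What is called first, only, known or untested is meant among the compounds shown, and "the series" means these compounds.

In a functional assay on L1210 cells (Mus musculus) for inhibition (on this read-out lower numbers stand for stronger inhibition and higher numbers for weaker inhibition), compound 1 `C=C1[C@@H](O)[C@H](n2cnc3c(Cl)nc(N)nc32)O[C@@H]1CO` gives 441000 nM and compound 3 `C=C1[C@@H](O)[C@H](n2cnc3c(OC)nc(N)nc32)O[C@@H]1CO` gives 446000 nM. Methoxy in place of chloro is a 1.0-fold higher number from compound 1 to compound 3 (0.00 log units; within the scatter), so compound 3 stands level with compound 1. Compound 2 `C=C1[C@@H](O)[C@H](n2cnc3c(N)nc(N)nc32)O[C@@H]1CO` shows only > 200000 nM, which is a limit of the assay and not a number.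

Compound 4 `C=C1[C@@H](O)[C@H](n2cnc3c(SC)nc(N)nc32)O[C@@H]1CO` carries methylsulfanyl in place of methoxy on an aromatic carbon. Among the compounds with values here, the only readable exchange on that carbon is a 1.0-fold higher number from compound 1 to compound 3 (0.00 log units; within the scatter), and it gives no reason to expect a shift in this assay. The expected change is a 1.0-fold lower number from compound 3 to compound 4 (0.02 log units; within the scatter), with no direction beyond the scatter. For compound 4 the estimate is 430000 nM, with an expected range of 200000 nM to 850000 nM.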

Compound 4, half-maximal inhibitory concentration: > 500000 nM
Compound 4: a limit, no number; the forecaster's own chance of this, stated with the estimate: 30%; at least 1.1-fold (0.06 log units) between middle value and limit.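

In this assay compound 4 is recorded only as a limit and not a number: the limit of > 500000 nM in this assay, at which 1 of the 4 values shown sits.

Even so, the exchange from methoxy gives an at least 1.1-fold higher number from compound 3 to compound 4 (0.04 log units; that floor lies within the scatter), and the exchange from chloro gives an at least 1.1-fold higher number from compound 1 to compound 4 (0.05 log units; that floor lies within the scatter), so methylsulfanyl on this carbon shows no sign of stronger inhibition than either group. The step between compound 2 and compound 4 cannot be read.

On these data alone, how far compound 4 lies past its limit stays open. So does whether a longer chain such as ethylsulfanyl, or a hydroxyl group, on this carbon would give stronger inhibition.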